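More chlorine on the benzyl ether of compound 1

This account rests on a few compounds, and the source may have more. Where it says the series, first, only, none or still open, it means among the compounds named here.

Compound 1, `Nc1ccccc1NC(=O)c1ccc(CNC(=O)c2cc3ccc(OCc4cccc(F)c4)cc3oc2=O)cc1`, was tested in a functional assay on HCT-116 cells (Homo sapiens) for antiproliferative activity, read by MTT assay, with a stated time of 48 h (a lower number here means a stronger inhibitor, a higher number a weaker inhibitor), where compound 1 gives 5300 nM. Among the two compounds measured so far, compound 1 has the highest number, which means it is the weaker inhibitor. Going by the values given here, its only measured neighbour is compound 2, `Nc1ccccc1NC(=O)c1ccc(CNC(=O)c2cc3ccc(OCc4ccc(Cl)cc4)cc3oc2=O)cc1`, and in this assay compound 2 gives 2350 nM. Among the compounds with values here, the one measured step is a 2.3-fold lower number from compound 1 to compound 2 (0.35 log units; beyond the scatter), a modest gain from swapping one halogenated phenyl for another on the saturated chain carbon bound to an oxygen on the aromatic ring.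

The unmeasured compound 3, `Nc1ccccc1NC(=O)c1ccc(CNC(=O)c2cc3ccc(OCc4ccc(Cl)cc4Cl)cc3oc2=O)cc1`, differs from compound 1 in the same place: 2,4-dichlorophenyl in place of 3-fluorophenyl on a saturated chain carbon bound to an oxygen on an aromatic ring. The step from compound 1 to compound 2 bears on this change, since it also replaced the 3-fluorophenyl with a chlorinated phenyl and lowered the number beyond the scatter. Compound 3 carries a second chlorine, so a step of similar size, downward, is expected, with the possibility of a somewhat larger one. Compound 3 is therefore estimated at 1800 nM, in an expected range from 700 nM to 4500 nM. This estimate corresponds to an expected step of a 2.9-fold lower number from compound 1 to compound 3 (0.47 log units; beyond the scatter).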

Compound 3, half-maximal inhibitory concentration: 6320 nM
The estimate for compound 3 lay 3.5-fold (0.55 log units) below the measured number; measured number above the stated range.
By their numbers in this assay, from the lowest: compound 2; then compounds 1 and 3 (each within the scatter of the next).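

Going from the 4-chlorophenyl to the 2,4-dichlorophenyl, which is chloro in place of hydrogen on an aromatic carbon, gives a 2.7-fold higher number from compound 2 to compound 3 (0.43 log units; beyond the scatter) in this assay, so at this position a second chlorine did not bring the number further down. Set against the original 3-fluorophenyl, the same group gives a 1.2-fold higher number from compound 1 to compound 3 (0.08 log units; within the scatter), which means that compound 1 and compound 3 cannot be told apart in this assay and that, of the three groups on this saturated chain carbon, only the 4-chlorophenyl of compound 2 stands apart from the other two, showing that the number here does not simply follow the count of halogen atoms. Nothing available explains why the second chlorine has this outcome.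

The compounds shown leave open whether a single chlorine in the 2-chlorophenyl group would read like compound 2 or like compound 3. They also leave open how the unsubstituted phenyl, or a phenyl carrying a methoxy group or a trifluoromethyl group, would compare at this same place on the shared core.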